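Sec-Butyl Added to the Nitro-Free Sulfonamide Compound

The compounds below may be only part of what the source reports. "The series", "measured", "known", "first", "only" and "open" are said of these compounds alone.

Compound 1 `CC(=O)c1ccc(NC(=O)CN(C(=O)c2ccccc2)S(=O)(=O)c2ccc([N+](=O)[O-])cc2)cc1` gives 20.6%.
Compound 2 `CCC(C)C(C(=O)Nc1ccc(C(C)=O)cc1)N(C(=O)c1ccccc1)S(=O)(=O)c1ccc([N+](=O)[O-])cc1` gives 31.7%.
Compound 3 `CC(=O)c1ccc(NC(=O)CN(C(=O)c2ccccc2)S(=O)(=O)c2ccccc2)cc1` gives 40.5%.

In a functional assay for inhibition, read by spectrophotometry, with a stated time of 20 min, tested at 2 mg/mL (a lower number here means a weaker effect, a higher number a stronger effect of the compound at the concentration tested), compound 3 stands at the top of the three numbers; its gap to compound 2 is within the scatter, its gap to compound 1 beyond it. Compound 4 `CCC(C)C(C(=O)Nc1ccc(C(C)=O)cc1)N(C(=O)c1ccccc1)S(=O)(=O)c1ccccc1` differs from compound 3 by sec-butyl in place of hydrogen on a saturated chain carbon bound to an amide-type nitrogen and a carbonyl carbon. The same change has been measured once already: a number 11.1 percentage points higher from compound 1 to compound 2 (beyond the scatter). The other step, a number 19.9 percentage points higher from compound 1 to compound 3 (beyond the scatter), concerns a different group and does not bear on this change. A modest rise of similar size is therefore expected, a number 10.5 percentage points higher from compound 3 to compound 4 (beyond the scatter). Compound 4 is estimated at 51%, with a likely range from 38% to 64%.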

Compound 4, a percentage reported as inhibition, at one concentration (the size of the read-out at that concentration, not a potency): 11.4%
Beside the measured number, compound 4's estimate is 39.6 percentage points above it; the measured number lies below the stated range.
By their numbers in this assay, from the lowest: compounds 4 and 1 (each within the scatter of the next); then compounds 2 and 3 (each within the scatter of the next).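

With sec-butyl in place of hydrogen on the saturated chain carbon, this assay gives a number 29.1 percentage points lower from compound 3 to compound 4 (beyond the scatter), so the direction of this change depends on the core carrying it: the same change on two cores in this assay, a number 11.1 percentage points higher (beyond the scatter) from compound 1 to compound 2 and a number 29.1 percentage points lower (beyond the scatter) from compound 3 to compound 4, 40.2 percentage points apart, beyond the scatter of two such steps. Hydrogen in place of nitro on an aromatic carbon also reverses direction when sec-butyl is present, giving a number 20.3 percentage points lower from compound 2 to compound 4 (beyond the scatter): the same change on two cores in this assay, a number 19.9 percentage points higher (beyond the scatter) from compound 1 to compound 3 and a number 20.3 percentage points lower (beyond the scatter) from compound 2 to compound 4, 40.2 percentage points apart, beyond the scatter of two such steps. Across these four compounds, the two changes therefore do not act independently.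

Going by these compounds, it remains open whether a methyl group or an amine on this chain carbon would follow the nitro-bearing or the nitro-free pair. These numbers also do not explain the reversal.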